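The source may report more compounds than this note shows. Statements on the series, on what has been measured and on what is new or still open speak of the compounds shown alone.

Measured so far:
compound 1, `O=C(/C=C/c1ccc2c(c1)B(O)OC2)c1ccco1` — 7300 nM
compound 2, `O=C(/C=C/c1ccc2c(c1)B(O)OC2)c1ccc(F)cc1` — 1600 nM
compound 3, `O=C(/C=C/c1ccc2c(c1)B(O)OC2)c1ccccc1O` — 16900 nM

All three share one core and differ only in the ring attached to the carbonyl carbon. In a functional assay on MDA-MB-231 cells (Homo sapiens) for cytotoxicity, read by MTT assay, with a stated time of 48 h (on this read-out lower numbers stand for stronger inhibition and higher numbers for weaker inhibition), compound 1 stands second highest of the three numbers: compound 2 gives a lower number, as the step of a 4.6-fold lower number from compound 1 to compound 2 (0.66 log units; beyond the scatter) shows, and compound 3 a higher one, as the step of a 2.3-fold higher number from compound 1 to compound 3 (0.36 log units; beyond the scatter) shows. The gap between those two rings is the step of an 11-fold higher number from compound 2 to compound 3 (1.02 log units; beyond the scatter).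

Compound 4, `O=C(/C=C/c1ccc2c(c1)B(O)OC2)c1cccc(O)c1`, is not yet measured. Its change from compound 1 is 3-hydroxyphenyl in place of furan-2-yl on a carbonyl carbon. Both measured steps from compound 1 bear on it: swapping the furan-2-yl for a six-membered carbon ring gave a modestly lower number with 4-fluorophenyl, but a modestly higher one with 2-hydroxyphenyl. The 3-hydroxyphenyl ring lies in between those two cases, so in this assay the expected step is a 1.2-fold lower number from compound 1 to compound 4 (0.09 log units; within the scatter), likely not beyond the scatter, with the direction uncertain. Compound 4 is therefore estimated at 6000 nM, within a range from 2000 nM to 18000 nM.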

Compound 4, half-maximal inhibitory concentration: 2700 nM
The estimate for compound 4 lay 2.2-fold (0.35 log units) above the measured number; measured number inside the range.
By their numbers in this assay, from the lowest: compounds 2 and 4 (each within the scatter of the next); then compound 1; then compound 3.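

In this assay, putting 3-hydroxyphenyl in place of 2-hydroxyphenyl gives a 6.3-fold lower number from compound 3 to compound 4 (0.80 log units; beyond the scatter) and so shows that a hydroxyl on the phenyl ring does not by itself bring the high number seen for compound 3: where it sits on the ring matters. Compound 4 also departs from compound 3 in its step from the furan-2-yl compound, with a 2.7-fold lower number from compound 1 to compound 4 (0.43 log units; beyond the scatter) in the same direction as the 4-fluorophenyl change. Replacing 4-fluorophenyl with 3-hydroxyphenyl gives a 1.7-fold higher number from compound 2 to compound 4 (0.23 log units; within the scatter) and lies within the scatter, so this assay does not separate these two rings.

From the compounds shown here alone, whether a methoxy group, an amine or a carboxylic acid on the phenyl ring would behave like the hydroxyl stays open. Nothing shown here explains why the hydroxyl's place on the ring matters so much.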